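A few compounds are considered here, and "the series" means these few. Any claim that something is new, unique, unknown or untested is made for them only; others in the source may bear on it.

Measured so far:
compound 1 `O=C1N(CCCCCCOc2ccc(C(F)(F)F)cc2)CCN1c1ccncc1` — > 25000 nM
compound 2 `O=C1N(CCCCCCOc2ccc(C(F)(F)F)cc2)CCN1c1cccnc1` — > 25000 nM

In a functional assay on cells (Homo sapiens) for cytotoxicity (a lower number here means that less compound is tolerated, a higher number that more compound is tolerated), compound 1 gives > 25000 nM, which is a limit of the assay rather than a number. Compound 2 in turn gives > 25000 nM, again a limit. Compound 2 thus stands where every measured value of the series sits, as shown by the limit of > 25000 nM in this assay, at which 2 of the 2 values shown sit. The step that the two limits leave unreadable from compound 1 to compound 2 cannot be read, since both of its ends are limits.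

Compound 3 `CC(C)(C)c1ccc(OCCCCCCN2CCN(c3cccnc3)C2=O)cc1` has not yet been measured. It differs from compound 2 by tert-butyl in place of trifluoromethyl on an aromatic carbon. Going by the values given here, no measured step touches this change, and the single step on record is unreadable, so the expectation rests on where compound 2 stands. Compound 3 is therefore expected to give 25000 nM, with a range from 12000 nM to 60000 nM. The step of a number no higher from compound 2 to compound 3 (the limit leaves the size open) that this estimate means is expected to stay within the scatter, and a limit rather than a number is the likelier read-out.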

Compound 3, half-maximal cytotoxic concentration: > 25000 nM
Compound 3 ended at the assay's limit; the forecaster's own chance of this, stated with the estimate: 85%; the middle value lies on the limit itself.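

The step between compound 2 and compound 3 cannot be read, since both of its ends are limits, and the whole series sits at one limit: the limit of > 25000 nM in this assay, at which 3 of the 3 values shown sit.

The compounds shown leave open how far each lies from that limit in this assay, and whether tert-butyl in place of trifluoromethyl changes the read-out at all.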